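The compounds below may be only part of what the source reports. "The series", "measured", "known", "first", "only" and "open" are said of these compounds alone.

Measured compounds:
compound 1, `Cc1nc(CCO)cc2nn(-c3ccccc3)cc12`, > 100000 nM
compound 2, `OCCc1cc2nn(-c3ccccc3)cc2cn1`, > 100000 nM
compound 3, `CCCCc1cc2nn(-c3ccccc3)cc2cn1`, 13300 nM

Of the compounds shown here, three sharing one core have been tested in a functional assay on MCF7 cells (Homo sapiens) for inhibition, read by fluorescence, with a stated time of 72 h; on this read-out lower numbers stand for stronger inhibition of growth and higher numbers for weaker inhibition of growth. Compound 1 gives only a limit of the assay, > 100000 nM. Compound 2 likewise gives only a limit, > 100000 nM. Compound 3 gives a real number, 13300 nM. Compound 1 thus stands at the limit where two of the three values sit (the limit of > 100000 nM in this assay, at which 2 of the 3 values shown sit), and no number for it is known.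

Compound 4, `Cc1nccc2nn(-c3ccccc3)cc12`, differs from compound 1 in one place: hydrogen in place of 2-hydroxyethyl on an aromatic carbon. Within the data shown here, two measured steps bear on this. One is a step that the two limits leave unreadable from compound 1 to compound 2, which gives no size. Among the measured compounds shown here, the other is an at least 7.5-fold lower number from compound 2 to compound 3 (0.87 log units; beyond the scatter), the only readable step, in which the hydroxy group left but a chain remained, whereas compound 4 loses the whole 2-hydroxyethyl chain. With compound 1 known only as a limit, compound 4 is expected to stay close to that limit, an estimated step of a number no higher from compound 1 to compound 4 (the limit leaves the size open). The estimated value of compound 4 in this assay is 100000 nM, within a range from 30000 nM to 400000 nM.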

Compound 4, concentration for 50% growth inhibition: > 100000 nM
Compound 4 gave a limit, no number (the forecaster's own chance of this, stated with the estimate: 75%); the middle value sits exactly at the limit.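

Among these compounds, compound 1 and compound 4 both give only a limit, not a number, in this assay, so no step between them can be read: the limit of > 100000 nM in this assay, at which 3 of the 4 values shown sit. The compounds shown leave open whether hydrogen in place of 2-hydroxyethyl changes growth inhibition at all, and in which direction.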